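The compounds below may be only part of what the source reports. "The series", "measured", "known", "first", "only" and "open" are said of these compounds alone.

Within a series built on a single shared core, carrying a trifluoromethoxy group on the pendant aryl ring and a methoxy group on the fused ring, two compounds have numbers in hand. Going by the values given here, in a functional assay on SKHep cells (Homo sapiens) for antiproliferative activity, read by MTT assay, with a stated time of 12 h (a higher number here means a weaker inhibitor, a lower number a stronger inhibitor), compound 2 `COc1cccc2oc(/C=C/c3ccc(OC(F)(F)F)cc3)cc(=O)c12` gives 21000 nM and is the only compound with a number rather than a limit. Compound 1 `COc1ccc2oc(/C=C/c3ccc(OC(F)(F)F)cc3)cc(=O)c2c1` gives in this assay > 40000 nM, which is a limit of the assay and not a number, a point recorded as the limit of > 40000 nM in this assay, at which 1 of the 2 values shown sits. Compound 3 `COc1cc(OC)c2c(=O)cc(/C=C/c3ccc(OC(F)(F)F)cc3)oc2c1` differs from compound 2 by methoxy in place of hydrogen on an aromatic carbon. Among the compounds with values here, no measured pair differing in one place is available, so the size of this step cannot be read from a precedent; the expectation is a change no larger than the usual scatter of this assay, with no direction preferred, written as a 1.1-fold lower number from compound 2 to compound 3 (0.02 log units; within the scatter). Compound 3 is therefore estimated to give 20000 nM in this assay, within a range from 7000 nM to 60000 nM.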

Compound 3, half-maximal inhibitory concentration: 12500 nM
For compound 3 the middle estimate is 1.6-fold (0.20 log units) above the measured one; the range from low to high includes it.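

In this assay the series now has its first readable step, which is a 1.7-fold lower number from compound 2 to compound 3 (0.23 log units; within the scatter) and comes from methoxy in place of hydrogen on an aromatic carbon, meta to a methoxy group and para to a fused ring. At this position, then, the added methoxy leaves compound 3 within the scatter of compound 2, and the two numbers do not separate them. Nothing shown here speaks to what lies behind this small step.

Going by these compounds alone, for compound 1 the value > 40000 nM is a limit of the assay and not a number, so no step from it can be read. On these data alone, whether an amine, a carboxylic acid or a longer chain on this same aromatic carbon would carry the number beyond the scatter remains open.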